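Methyl on the Indole Nitrogen and Solubility

This account rests on a few compounds, and the source may have more. Where it says the series, first, only, none or still open, it means among the compounds named here.

Four compounds share a fused two-ring core. Compound 1 `CN(C)C(=O)c1c[nH]c2ccccc12` carries a dimethylcarbamoyl group on that core. Compound 2 `O=C(Cn1ccccc1=O)Nc1cc2ccccc2[nH]1` carries a larger amide-linked group, and the difference between the two cores is not broken down here. Compound 3 `Cn1c(NC(=O)Cn2ccccc2=O)cc2ccccc21` arises from compound 2 through (methyl in place of hydrogen on an aromatic nitrogen). Compound 4 `CN(C)C(=O)c1cn(C)c2ccccc12`, not yet measured, arises from compound 1 through (methyl in place of hydrogen on an aromatic nitrogen). The two "place" descriptions do not match word for word: in one the methyl sits next to the ring atom that bears a large group, in the other two ring bonds from the ring atom that bears a dimethylcarbamoyl group, so the two changes are the same kind of change, not the same.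

In a physicochemical assay for solubility, with a stated time of 24 h, at pH 6.8 (on this read-out higher numbers stand for higher solubility and lower numbers for lower solubility), compound 1 gives > 44 ug/mL, which is a limit of the assay rather than a number, as the limit of > 44 ug/mL in this assay, at which 1 of the 3 values shown sits, states. In this assay compound 2 gives > 67 ug/mL, again a limit, as the limit of > 67 ug/mL in this assay, at which 1 of the 3 values shown sits, states. Compound 3 gives 3 ug/mL in this assay. The measured step is an at least 22-fold lower number from compound 2 to compound 3 (1.34 log units; beyond the scatter).

For compound 4 the expected value in this assay is 15 ug/mL, with a range estimated from 4 ug/mL to 60 ug/mL. This expectation means an at least 2.9-fold lower number from compound 1 to compound 4 (0.46 log units; beyond the scatter), and it rests on an at least 22-fold lower number from compound 2 to compound 3 (1.34 log units; beyond the scatter) together with the starting limit of compound 1, > 44 ug/mL.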

Compound 4, solubility: > 51 ug/mL
Compound 4 was reported as a limit (the forecaster's own chance of this, stated with the estimate: 20%); middle value at least 3.4-fold (0.53 log units) from the limit.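

Among the compounds shown here, compound 1 and compound 4 both stand as limits in this assay, not as numbers, so the step between them cannot be read and no new step comes from this result. The compounds shown leave open how large the change from hydrogen to methyl on the aromatic nitrogen is in this pair, and whether it comes near an at least 22-fold lower number from compound 2 to compound 3 (1.34 log units; beyond the scatter).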